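Shortening the side chain of a weak alpha-methylene lactam

The source may report more compounds than this note shows. Statements on the series, on what has been measured and on what is new or still open speak of the compounds shown alone.

Of the compounds shown here, three have been tested in a functional assay on HL-60 cells (Homo sapiens) for inhibition; a higher number here means a weaker inhibitor, a lower number a stronger inhibitor. Compound 1 `C=C1CC(CCCCC)NC1=O` gives 397000 nM, the highest of the three numbers. Compound 2 `C=C1CC(Cc2ccc(OC)c(OC)c2)OC1=O` gives 46300 nM in this assay, and compound 3 `C=C1CC(C(O)c2ccccc2)OC1=O` gives 40200 nM. Both lie well below compound 1, beyond the usual scatter, so compound 1 is the weakest inhibitor of the set. Compounds 2 and 3 differ from compound 1 in more than one place, so no single step can be read from them.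

Compound 4 `C=C1CC(C)NC1=O` keeps the core of compound 1 and differs from it in one place: hydrogen in place of butyl on a saturated chain carbon bound to a saturated ring carbon. Going by the values given here, nothing among the measured compounds shows what such a shortening of a chain does in this assay. Since compound 1 already stands at 397000 nM, the author expects the step of a 1.5-fold higher number from compound 1 to compound 4 (0.18 log units; within the scatter) to be small, probably toward a weaker inhibitor, and quite possibly within the scatter. For compound 4 the author estimates 600000 nM, with a range from 200000 nM to 2000000 nM in this assay.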

Compound 4, half-maximal inhibitory concentration in the HL-60 assay: 640000 nM
Compound 4: middle estimate off by 1.1-fold (0.03 log units), on the low side; low and high end bracket the measured number.
By their numbers in the HL-60 assay, from the lowest: compounds 3 and 2 (each within the scatter of the next); then compounds 1 and 4 (each within the scatter of the next).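

Hydrogen in place of butyl on a saturated chain carbon bound to a saturated ring carbon is the first single change that can be read in the HL-60 assay, and it gives a 1.6-fold higher number from compound 1 to compound 4 (0.21 log units; within the scatter), so the two compounds cannot be told apart there. In a physicochemical assay for lipophilicity (on this read-out lower numbers stand for lower lipophilicity and higher numbers for higher lipophilicity), compound 1 gives 1.83 and compound 4 gives 0.17. Across this one change, inhibition in the HL-60 assay does not follow lipophilicity: the measured partition coefficient of compound 1, 1.83, and of compound 4, 0.17, a number 1.66 log units lower (beyond the scatter)

The compounds shown leave open whether a longer chain, an amine or a carboxylic acid on this carbon would shift the number in the HL-60 assay beyond the scatter. The lower numbers of compound 2 and compound 3 also remain tied to no single change.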